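Trading an aryl ring for isobutyl: an expected value

This account rests on a few compounds, and the source may have more. Where it says the series, first, only, none or still open, it means among the compounds named here.

Of the compounds shown here, three with one shared core have been tested in an assay on isolated protein (Cavia porcellus) with Sigma non-opioid intracellular receptor 1 (Homo sapiens) as the target, read by radioligand binding; on this read-out lower numbers stand for stronger inhibition and higher numbers for weaker inhibition. Compound 1 `O=c1cc(-c2ccccc2Cl)oc2ccc(OCCCCCCN3CCC(O)CC3)cc12` gives 29 nM, compound 2 `COc1ccc(-c2cc(=O)c3cc(OCCCCCN4CCC(O)CC4)ccc3o2)cc1` gives 600 nM, and compound 3 `COc1ccc(-c2cc(=O)c3cc(OCCCCCCN4CCC(O)CC4)ccc3o2)cc1` gives 332 nM. Compound 2 thus carries the highest number of the three; it lies within the scatter of compound 3, as a 1.8-fold lower number from compound 2 to compound 3 (0.26 log units; within the scatter) shows, while its gap to compound 1 is beyond the scatter.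

Compound 4 `CC(C)Cc1cc(=O)c2cc(OCCCCCN3CCC(O)CC3)ccc2o1` differs from compound 2 by isobutyl in place of 4-methoxyphenyl on an aromatic carbon. One measured step changes that same position, an 11-fold higher number from compound 1 to compound 3 (1.06 log units; beyond the scatter), a large move, so the position clearly matters. The chain step a 1.8-fold lower number from compound 2 to compound 3 (0.26 log units; within the scatter) bears little on it. Within the data shown here, with no isobutyl example measured, the direction is uncertain, and no step beyond the scatter is expected, a 1.2-fold higher number from compound 2 to compound 4 (0.07 log units; within the scatter). Compound 4 is therefore estimated at 700 nM, within a range from 150 nM to 3500 nM.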

Compound 4, half-maximal inhibitory concentration: 261 nM
Beside the measured number, compound 4's estimate is 2.7-fold (0.43 log units) above it; low and high end bracket the measured number.
By their numbers in this assay, from the lowest: compound 1; then compounds 4, 3 and 2 (each within the scatter of the next, the first and the last beyond it).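

In this assay, isobutyl in place of 4-methoxyphenyl gives a 2.3-fold lower number from compound 2 to compound 4 (0.36 log units; beyond the scatter), a modest step. Until now this position had carried only aryl rings, and here a group with no ring and no hydrogen-bond acceptor gives a lower number than 4-methoxyphenyl does on the same core. Nothing measured here explains this step.

The compounds shown leave open how a methyl or a cyclohexyl group would read at this position. They also leave open whether isobutyl would give a similar step on the longer chain of compound 3.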